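This account rests on a few compounds, and the source may have more. Where it says the series, first, only, none or still open, it means among the compounds named here.

Compound 1 `COc1cc(N)c(Cl)cc1NC(=O)C1CCN(Cc2ccc(Cl)cc2)CC1`: 1.2 mg/kg
Compound 2 `COc1cc(N)c(Cl)cc1NC(=O)C1CCN(CC2CCCC2)CC1`: a limit, > 10 mg/kg
Compound 3 `CCCCCN1CCC(C(=O)Nc2cc(Cl)c(N)cc2OC)CC1`: a limit, > 10 mg/kg

In a functional assay on the whole organism for antagonist activity, with Mus musculus as the target (on this read-out higher numbers stand for an effect only at larger amounts of compound and lower numbers for an effect already at smaller amounts), compound 1 gives 1.2 mg/kg. Compound 2 reaches only a limit of the assay, > 10 mg/kg. Compound 3 likewise reaches only a limit, > 10 mg/kg. Thus compound 3 sits at the limit of > 10 mg/kg in this assay, at which 2 of the 3 values shown sit, and the step of an at least 8.3-fold higher number from compound 1 to compound 3 (0.92 log units; beyond the scatter) places it clearly weaker than compound 1.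

Compound 4 `COc1cc(N)c(Cl)cc1NC(=O)C1CCN(Cc2ccc(O)cc2)CC1` differs from compound 3 by 4-hydroxyphenyl in place of butyl on a saturated chain carbon bound to an amine nitrogen in a ring. This runs opposite to the change behind an at least 8.3-fold higher number from compound 1 to compound 3 (0.92 log units; beyond the scatter), where loss of the aromatic ring raised the number; an aromatic ring returns here, though carrying a hydroxyl rather than chlorine. A lower number is therefore expected, an at least 2.5-fold lower number from compound 3 to compound 4 (0.39 log units; beyond the scatter), though smaller than the full return to compound 1. Compound 4 is estimated at 4 mg/kg, with a range from 1.5 mg/kg to 15 mg/kg.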

Compound 4, dose for half-maximal effect: > 8 mg/kg
Compound 4 gave a limit, no number; the forecaster's own chance of this, stated with the estimate: 35%; middle value at least 2.0-fold (0.30 log units) away from the limit.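

Keeping the aromatic ring but putting hydroxy in place of chloro on an aromatic carbon gives an at least 6.6-fold higher number from compound 1 to compound 4 (0.82 log units; beyond the scatter), so the ring alone does not bring back the value of compound 1. In this assay compound 4 stops at a limit, not a number: the limit of > 8 mg/kg in this assay, at which 1 of the 4 values shown sits.

On these data alone, the steps to compound 4 from compound 2 and from compound 3 cannot be read, so whether 4-hydroxyphenyl differs at all from cyclopentyl or butyl stays open. Also open, as far as these compounds go, is how fluoro, methyl or an amine in place of chloro would read.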